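This account rests on a few compounds, and the source may have more. Where it says the series, first, only, none or still open, it means among the compounds named here.

Compound 1 `CC(C)CSc1nc(N)nc2c1ncn2/C=C1/CC1(CO)CO` gives 60000 nM in an ADME assay on CCRF-HSB-2 cells (Homo sapiens) for cytotoxicity, with a stated time of 7 days; a lower number here means that less compound is tolerated, a higher number that more compound is tolerated. Compound 2 `C=CCOc1nc(N)nc2c1ncn2/C=C1/CC1(CO)CO` gives only a limit of that assay, > 20000 nM. Compound 3 `CC(C)Nc1nc(N)nc2c1ncn2/C=C1/CC1(CO)CO` likewise gives only a limit, > 20000 nM. Compound 2 thus stands at the limit of > 20000 nM in this assay, at which 2 of the 3 values shown sit, and no step can be read from it: the change a step that the limit leaves unreadable from compound 1 to compound 2, the change a step that the limit leaves unreadable from compound 1 to compound 3 and the change a step that the two limits leave unreadable from compound 2 to compound 3 are all left unreadable by these limits. Compound 4 `Nc1nc(NC2CCCC2)c2ncn(/C=C3/CC3(CO)CO)c2n1` is not yet measured; it differs from compound 2 by cyclopentylamino in place of allyloxy on an aromatic carbon. For the measured compounds named here, none of the measured steps gives a readable size, so no direction is expected beyond the scatter of this assay. Compound 4 is estimated to give 30000 nM, within a range from 10000 nM to 100000 nM, and the expected step that the limit leaves unreadable from compound 2 to compound 4 is thought to stay within that scatter.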

Compound 4, half-maximal cytotoxic concentration: > 20000 nM
Compound 4 ended at the assay's limit; the forecaster's own chance of this, stated with the estimate: 60%; the middle value is on the limit's open side.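

No step from compound 1, compound 2 or compound 3 to compound 4 can be read, because compound 4 also ends at a limit: the limit of > 20000 nM in this assay, at which 3 of the 4 values shown sit.

As far as these compounds go, how far compound 2, compound 3 and compound 4 truly lie from compound 1, or from one another, in this assay stays open.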